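The source may report more compounds than this note shows. Statements on the series, on what has been measured and on what is new or still open speak of the compounds shown alone.

Working notes on the series. Within the data shown here, the three compounds with numbers so far share one core, varied at two points: the benzyl ring and the carbon of the fused ring system that sits between two ring nitrogen atoms. Compound 1 `CSc1ccc(CNc2nc([Se]C)nc3ccccc23)cc1` gives 54100 nM in a functional assay on MCF7 cells (Homo sapiens) for cytotoxicity, read by MTT assay, with a stated time of 72 h; on this read-out lower numbers stand for stronger inhibition of growth and higher numbers for weaker inhibition of growth. Compound 2 `Sc1nc(NCc2ccccc2)c2ccccc2n1` gives 27200 nM in this assay, the second highest of the three numbers; its nearest neighbour is compound 1, within the scatter, and its furthest is compound 3 `COc1ccc(CNc2nc(S)nc3ccccc23)cc1`, which gives 7080 nM in this assay. Among the measured compounds shown here, the one measured step, a 3.8-fold lower number from compound 2 to compound 3 (0.58 log units; beyond the scatter), is modest and concerns methoxy in place of hydrogen on the benzyl ring.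

Compound 4 `C[Se]c1nc(NCc2ccccc2)c2ccccc2n1` differs from compound 2 at the other point: a group of 2 heavy atoms (1 carbon, 1 selenium; no ring) in place of one sulfur atom, on an aromatic carbon. For the measured compounds named here, no measured step bears on this change directly. Compound 1 carries the same methylselanyl group but also a methylthio on the benzyl ring, so it differs from compound 2 in two places; all its two values show is that compound 1 and compound 2 lie within the scatter of each other. On that basis no step beyond the scatter is expected in this assay for compound 4, in either direction. The estimate for compound 4 is 38000 nM, with a range from 14000 nM to 105000 nM, which means an expected step of a 1.4-fold higher number from compound 2 to compound 4 (0.15 log units; within the scatter).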

Compound 4, concentration for 50% growth inhibition: 15800 nM
The estimate for compound 4 lay 2.4-fold (0.38 log units) above the measured number, within the range that was stated.
By their numbers in this assay, from the lowest: compound 3; then compounds 4, 2 and 1 (each within the scatter of the next, the first and the last beyond it).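

On the aromatic carbon between two ring nitrogen atoms, the change from sulfanyl to methylselanyl now has a direct reading in this assay: a 1.7-fold lower number from compound 2 to compound 4 (0.24 log units; within the scatter), so with an unsubstituted benzyl ring this exchange gives no step beyond the scatter. With methylselanyl held in place, the benzyl ring also has its first reading: a 3.4-fold lower number from compound 1 to compound 4 (0.53 log units; beyond the scatter), so for this pair the benzyl ring carries the step beyond the scatter. Substitution on that ring does not run in one direction across the pairs shown, since methoxy goes with a lower number in the sulfanyl pair (compounds 2 and 3), while methylsulfanyl goes with a higher number in the methylselanyl pair (compounds 4 and 1), although these pairs differ in both the ring group and the group on the fused ring system. No measurement offers an explanation for these numbers.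

The exchange changes both the heavy atoms and their number, so a methylsulfanyl group on that carbon would be needed to separate the selenium atom from the added carbon. Going by these compounds, whether an amine or a longer chain on that carbon would stay within the scatter of compound 2 remains open.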